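Bromine Added to the Weakest Member of the Series

The compounds below may be only part of what the source reports. "The series", "measured", "known", "first", "only" and "open" are said of these compounds alone.

Compound 3 `COc1ccc(C2=NN(C3=NC(=O)/C(=C4\C(=O)Nc5ccccc54)S3)C(c3ccc(Cl)cc3)C2)cc1` gives 100000 nM in a functional assay on cells (Cancer cell lines, Homo sapiens) for cytotoxicity, read by sulforhodamine B assay, with a stated time of 48 h (on this read-out higher numbers stand for weaker inhibition of growth and lower numbers for stronger inhibition of growth), the highest number among the three measured compounds. Compound 2 `O=C1N=C(N2N=C(c3ccccc3)CC2c2ccc(Cl)cc2)S/C1=C1/C(=O)Nc2ccccc21` gives 320 nM, and compound 1 `COc1ccc(C2=NN(C3=NC(=O)/C(=C4\C(=O)Nc5ccc(Br)cc54)S3)C(c3ccc(OC)cc3)C2)cc1` gives 210 nM. Going by the values given here, the only measured step that touches compound 3 directly is a 310-fold higher number from compound 2 to compound 3 (2.49 log units; beyond the scatter). Compound 4 `COc1ccc(C2=NN(C3=NC(=O)/C(=C4\C(=O)Nc5ccc(Br)cc54)S3)C(c3ccc(Cl)cc3)C2)cc1` differs from compound 3 by bromo in place of hydrogen on an aromatic carbon. Among the compounds with values here, no measured pair isolates this change: compound 1 carries the same bromo group but a methoxy where compound 4 carries chloro, and its number lies far below that of compound 3, so the bromo group appears in a potent compound, though that comparison spans two changes at once. Compound 4 is therefore expected to give 3000 nM within a range of 200 nM to 60000 nM. The expected step is a 33-fold lower number from compound 3 to compound 4 (1.52 log units; beyond the scatter), with wide uncertainty.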

Compound 4, concentration for 50% growth inhibition: 140 nM
The estimate for compound 4 lay 21-fold (1.33 log units) above the measured number; measured number outside the range, below it.
By their numbers in this assay, from the lowest: compounds 4, 1 and 2 (each within the scatter of the next, the first and the last beyond it); then compound 3.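

In this assay, bromo in place of hydrogen on an aromatic carbon of the fused system gives a 710-fold lower number from compound 3 to compound 4 (2.85 log units; beyond the scatter), so this single change is now seen alone and is large. With bromo in place, chloro in place of methoxy gives a 1.5-fold lower number from compound 1 to compound 4 (0.18 log units; within the scatter), which stays within the scatter. Nothing measured here explains the size of the bromo step. As far as these compounds go, whether fluoro, iodo, an amine or a carboxylic acid at this position would act like bromo remains open. So does whether bromo would have a similar effect on compound 2, which lacks the methoxy group.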